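A few compounds are considered here, and "the series" means these few. Any claim that something is new, unique, unknown or untested is made for them only; others in the source may bear on it.

Measured in an ADME assay on HepG2 2.2.15 cells (Homo sapiens) for cytotoxicity, read by MTT assay; a lower number here means that less compound is tolerated, a higher number that more compound is tolerated:
Compound 1 `COc1cc(/C=C/C(=O)Oc2ccc(C(C)=O)cc2)cc(OC)c1OC`: > 2420000 nM (a limit)
Compound 2 `CC(=O)c1ccc(OC(=O)/C=C/c2ccc(F)cc2)cc1`: > 3310000 nM (a limit)
Compound 3 `CC(=O)c1ccc(O[C@@H]2O[C@H](COC(=O)/C=C/c3cccc(F)c3)[C@@H](O)[C@H](O)[C@H]2O)cc1`: 828000 nM

Of these three results, only compound 3 has an actual number, 828000 nM. The result for compound 1 is a limit and not a number. The same holds for compound 2.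

Compound 4 `CC(=O)c1ccc(O[C@@H]2O[C@H](COC(=O)c3ccco3)[C@@H](O)[C@H](O)[C@H]2O)cc1` is the next to be tested in this assay. It differs from compound 3 in one place, with furan-2-yl in place of 2-(3-fluorophenyl)ethenyl on a carbonyl carbon. Among the compounds with values here, no measured pair shows a change of this kind, so the expectation rests on compound 3 and its value of 828000 nM. A modest shift towards more compound being tolerated is expected, though it may not clearly exceed the usual scatter. The expected change is a 1.7-fold higher number from compound 3 to compound 4 (0.23 log units; within the scatter). Compound 4 is estimated at 1400000 nM, with an expected range from 600000 nM to 3300000 nM.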

Compound 4, half-maximal cytotoxic concentration: 1170000 nM
Beside the measured number, compound 4's estimate is 1.2-fold (0.08 log units) above it; the range from low to high includes it.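

Within the data shown here, replacing 2-(3-fluorophenyl)ethenyl with furan-2-yl on a carbonyl carbon is the first single change that can be read in this assay, and it gives a 1.4-fold higher number from compound 3 to compound 4 (0.15 log units; within the scatter) as its step. At this position, a six-membered aromatic ring of carbon only, carrying fluorine and joined through a double bond, gives way to a five-membered aromatic ring with one hetero atom, and the two results cannot be told apart. Nothing measured here bears on why these two groups read alike.

On these data alone, whether this position accepts a group without an aromatic ring stays open, as an amine, a carboxylic acid or a longer saturated carbon chain on the same carbonyl carbon would show. A single pair also leaves open whether the same exchange would read alike on a different core.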